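Chain-substituent variation on the shared core: toward compound 4

The source may hold more compounds than are shown below. What is called first, only, known or untested is meant among the compounds shown, and "the series" means these compounds.

Three compounds in the series share one core and differ only in the group carried on the chain attached to the saturated ring. Compound 1 `Cn1ncc(Cl)c1-c1cc(C(=O)N[C@@H]2CN[C@H](CCN3CCC(O)CC3)C[C@H]2c2ccc(Cl)c(Cl)c2)oc1Cl` gives 15900 nM in a functional assay on OVCAR-8 cells (Homo sapiens) for antiproliferative activity; a higher number here means a weaker inhibitor, a lower number a stronger inhibitor. Compound 2 `Cn1ncc(Cl)c1-c1cc(C(=O)N[C@@H]2CN[C@H](CCN3CCCC3)C[C@H]2c2ccc(Cl)c(Cl)c2)oc1Cl` gives 1840 nM in this assay, and compound 3 `COCC[C@@H]1C[C@@H](c2ccc(Cl)c(Cl)c2)[C@H](NC(=O)c2cc(-c3c(Cl)cnn3C)c(Cl)o2)CN1` gives 1060 nM. Compound 3 thus stands at the lowest number of the three; its gap to compound 2, a 1.7-fold lower number from compound 2 to compound 3 (0.24 log units; within the scatter), is within the scatter, whereas a 15-fold lower number from compound 1 to compound 3 (1.18 log units; beyond the scatter) and an 8.6-fold lower number from compound 1 to compound 2 (0.94 log units; beyond the scatter) are both beyond it.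

Compound 4 `Cn1ncc(Cl)c1-c1cc(C(=O)N[C@@H]2CN[C@H](CC(=O)NCC(O)CO)C[C@H]2c2ccc(Cl)c(Cl)c2)oc1Cl` is not yet measured. Relative to compound 3 the change is (2,3-dihydroxypropyl)carbamoyl in place of methoxymethyl on a saturated chain carbon bound to a saturated ring carbon. The measured steps that bear on this are the two made at the same chain, where 4-hydroxypiperidin-1-yl gave way to methoxy, a 15-fold lower number from compound 1 to compound 3 (1.18 log units; beyond the scatter), and to pyrrolidin-1-yl, an 8.6-fold lower number from compound 1 to compound 2 (0.94 log units; beyond the scatter); in both the number fell when the larger group left. Compound 4 runs the other way, a larger group entering where methoxymethyl stood, so a step back upward toward the number of compound 1 is expected, a 7.5-fold higher number from compound 3 to compound 4 (0.88 log units; beyond the scatter). Compound 4 is therefore expected to give 8000 nM in this assay, within a range of 2500 nM to 25000 nM.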

Compound 4, half-maximal inhibitory concentration: 5900 nM
The estimate for compound 4 lay 1.4-fold (0.13 log units) above the measured number, within the range that was stated.
By their numbers in this assay, from the lowest: compounds 3 and 2 (each within the scatter of the next); then compound 4; then compound 1.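

Working from the chain on the saturated ring, the two hydroxyl-bearing groups now give the two highest numbers in this assay, with no exception among the four compounds: replacing methoxymethyl with (2,3-dihydroxypropyl)carbamoyl costs a 5.6-fold higher number from compound 3 to compound 4 (0.75 log units; beyond the scatter), and the comparison with the pyrrolidine compound gives a 3.2-fold higher number from compound 2 to compound 4 (0.51 log units; beyond the scatter). Ring size is therefore not needed for a rise at this place, since the entering group has no ring, yet this acyclic group does not go as high as the 4-hydroxypiperidin-1-yl group, with a 2.7-fold lower number from compound 1 to compound 4 (0.43 log units; beyond the scatter). Nothing at hand explains these differences.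

The compounds shown do not separate the contribution of the amide from that of the two hydroxyl groups in compound 4; a methylcarbamoyl or a hydroxymethyl group at this place would pull the two apart. They also leave open how a carboxylic acid or a primary amine at the end of this chain would read in this assay, and whether a longer chain would change the picture.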